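Fluorine position on the terminal phenyl of the urea

The source may hold more compounds than are shown below. What is called first, only, known or untested is meant among the compounds shown, and "the series" means these compounds.

Three compounds of the shared core have numbers in a functional assay on MDA-MB-231 cells (Homo sapiens) for cytotoxicity, read by MTT assay, with a stated time of 72 h; a higher number here means a weaker inhibitor, a lower number a stronger inhibitor. Compound 1 `CN(C)CCCNc1nc(-c2ccc(NC(=O)Nc3ccccc3F)cc2)nc2ccsc12` gives 660 nM, compound 2 `CN(C)CCNc1nc(-c2ccc(NC(=O)Nc3ccccc3F)cc2)nc2ccsc12` gives 600 nM and compound 3 `CCN(CC)CCCNc1nc(-c2ccc(NC(=O)Nc3ccc(F)cc3)cc2)nc2ccsc12` gives 530 nM. Among the measured compounds shown here, the one measured step, a 1.1-fold lower number from compound 1 to compound 2 (0.04 log units; within the scatter), changes nothing beyond the scatter. Compound 3 stands alongside compounds 1 and 2: the gaps among the three numbers are all within the scatter, so no order among them is established.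

Compound 4 `CCN(CC)CCCNc1nc(-c2ccc(NC(=O)Nc3ccccc3F)cc2)nc2ccsc12` is not yet measured. The change from compound 3 is 2-fluorophenyl in place of 4-fluorophenyl on an amide-type nitrogen. For the measured compounds named here, no measured pair isolates this change: compounds 1 and 2 carry the 2-fluorophenyl together with a different amine chain, so their values can only be read as the same fluorophenyl sitting near compound 3 in this assay. On that basis no step beyond the scatter is expected, a 1.1-fold higher number from compound 3 to compound 4 (0.05 log units; within the scatter). Compound 4 is therefore estimated at 600 nM in this assay, within a range from 300 nM to 1200 nM.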

Compound 4, half-maximal inhibitory concentration: 860 nM
Beside the measured number, compound 4's estimate is 1.4-fold (0.16 log units) below it; the measured number falls inside the stated range.
By their numbers in this assay, from the lowest: compounds 3, 2, 1 and 4 (each within the scatter of the next).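

Among the compounds shown here, the pair of compound 3 and compound 4 is the first to isolate the fluorine position: in this assay, 2-fluorophenyl in place of 4-fluorophenyl on an amide-type nitrogen gives a 1.6-fold higher number from compound 3 to compound 4 (0.21 log units; within the scatter). With the 2-fluorophenyl held constant, the amine chain can also be read: (diethylamino)methyl in place of dimethylamino gives a 1.4-fold higher number from compound 2 to compound 4 (0.16 log units; within the scatter), and diethylamino in place of dimethylamino gives a 1.3-fold higher number from compound 1 to compound 4 (0.11 log units; within the scatter). Neither the fluorine position nor these amine chain changes therefore separates any pair beyond the scatter in this assay.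

Still open, on these data alone, is how an unsubstituted phenyl or a chlorophenyl on the urea, or a morpholine or piperidine at the chain end, would read. No supporting measurement bears on the result beyond these numbers.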